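The compounds below may be only part of what the source reports. "The series", "measured", "known", "first", "only" and "open" are said of these compounds alone.

For the measured compounds named here, in a functional assay (Homo sapiens) for antiproliferative activity (a lower number here means a stronger inhibitor of growth, a higher number a weaker inhibitor of growth), only two compounds with this shared core have numbers so far. Compound 1 `N=C(N)N/N=C/c1c(-c2ccccn2)nc2sc(Cl)cn12`, which carries pyridin-2-yl, gives 8910 nM, and compound 2 `N=C(N)N/N=C/c1c(-c2cccnc2)nc2sc(Cl)cn12`, which carries pyridin-3-yl, gives 16600 nM. Going by the values given here, these two values lie within the usual scatter of each other, so compound 2 cannot be told apart from the only other compound measured. Compound 3 `N=C(N)N/N=C/c1c(-c2ccncc2)nc2sc(Cl)cn12` keeps the core and makes one change to compound 2: pyridin-4-yl in place of pyridin-3-yl on an aromatic carbon. The two have the same atoms, joined differently. Among the compounds with values here, only one measured step bears on this change, the similar exchange of one pyridinyl group for another, a 1.9-fold higher number from compound 1 to compound 2 (0.27 log units; within the scatter). That step lies within the scatter, and a single step is thin evidence, so no shift in either direction is expected in this assay. The expected size of a 1.2-fold lower number from compound 2 to compound 3 (0.07 log units; within the scatter) therefore stays within the scatter. The estimate for compound 3 is 14000 nM, with an expected range of 6000 nM to 32000 nM.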

Compound 3, concentration for 50% growth inhibition: 13200 nM
The estimate for compound 3 lay 1.1-fold (0.03 log units) above the measured number; measured number inside the range.
By their numbers in this assay, from the lowest: compounds 1, 3 and 2 (each within the scatter of the next).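

With pyridin-4-yl now measured, three pyridinyl groups can be compared at this aromatic carbon in this assay. Exchanging pyridin-3-yl for pyridin-4-yl gives a 1.3-fold lower number from compound 2 to compound 3 (0.10 log units; within the scatter), and exchanging pyridin-2-yl for pyridin-4-yl gives a 1.5-fold higher number from compound 1 to compound 3 (0.17 log units; within the scatter). Together with the earlier step, these results show that, for these three compounds, the place of the nitrogen in the pyridine ring makes no difference that this assay can resolve, so the three cannot be ranked, and no other measurement here bears on this result.

For the compounds shown here, every group at this position so far is a six-membered aromatic ring with one ring nitrogen, so it remains open whether the ring nitrogen matters at all, which a plain phenyl ring would test, or whether a quite different group, such as a methyl group or an amine, would move the number beyond the scatter. As far as these compounds go, it is also open whether this indifference to the place of the nitrogen would hold if the chlorine on the shared core were exchanged for another group, such as a methyl group.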